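A few compounds are considered here, and "the series" means these few. Any claim that something is new, unique, unknown or untested is made for them only; others in the source may bear on it.

Measured in an ADME assay on Raji cells (Homo sapiens) for cytotoxicity, with a stated time of 72 h; on this read-out higher numbers stand for an effect only at larger amounts of compound and lower numbers for an effect already at smaller amounts:
- Compound 1 `CC(=O)c1ccc(NC(=O)Nc2cc(C)nc3ccccc23)cc1`: > 25000 nM (a limit)
- Compound 2 `Cc1cc(NC(=O)Nc2ccc(F)c(F)c2)c2ccccc2n1`: > 25000 nM (a limit)
- Compound 3 `CSc1ccccc1NC(=O)Nc1cc(C)nc2ccccc12`: > 25000 nM (a limit)

Compound 1 gives no number, only the limit > 25000 nM as its reading. It has no place above or below compound 2 or compound 3, which also stand at a limit. The whole picture so far is the limit of > 25000 nM in this assay, at which 3 of the 3 values shown sit, and nothing finer. Going by the values given here, no step between measured compounds is available.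

Compound 4 `Cc1cc(NC(=O)Nc2ccc(C(F)(F)F)cc2)c2ccccc2n1` is still to be measured. It has trifluoromethyl in place of acetyl on an aromatic carbon, para to a large group trifluoromethyl in place of acetyl on an aromatic carbon and otherwise keeps the structure of compound 1.

The expectation rests on compound 1 and its limit of > 25000 nM as the only anchor. The step expected in this assay is a number no higher from compound 1 to compound 4 (the limit leaves the size open) and is estimated to be none beyond the scatter, so another limit is the likeliest result. For compound 4 the estimated value is 25000 nM with an expected range from 8000 nM to 30000 nM as its span.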

Compound 4, half-maximal effective concentration: 23000 nM
Beside the measured number, compound 4's estimate is 1.1-fold (0.04 log units) above it; the range from low to high includes it.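

In this assay, going by these compounds alone, compound 4 gives 23000 nM, the first reading in this set that is a number and not a limit, and it carries trifluoromethyl in place of acetyl on an aromatic carbon, para to a large group. The step reads an at least 1.0-fold lower number from compound 1 to compound 4 (0.03 log units; that floor lies within the scatter); only this floor can be read, since compound 1 stands at a limit, so the change of group may amount to little or to much more. The picture is still dominated by that ceiling, and compound 4 is the only one with a number to set against it: the limit of > 25000 nM in this assay, at which 3 of the 4 values shown sit.

The compounds shown leave open how far compound 1 actually lies past its limit, so the true size of this step remains unknown. They also leave open whether another group at this place, such as an amine or a carboxylic acid, would give a reading at smaller amounts of compound.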